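A few compounds are considered here, and "the series" means these few. Any claim that something is new, unique, unknown or untested is made for them only; others in the source may bear on it.

Working notes on the series. Compound 1, `O=C(CN1CCCCC1)Nc1ccc(-c2nc3cc(C(F)(F)F)ccc3[nH]2)cc1`, is the reference point. Within the data shown here, in an ADME assay on MT4 cells (Homo sapiens) for cytotoxicity, read by MTT assay, with a stated time of 96 h (a lower number here means that less compound is tolerated, a higher number that more compound is tolerated), compound 1 gives 6000 nM, the lowest of the three numbers measured so far. Among the measured compounds shown here, compound 2, `O=[N+]([O-])c1ccc(-c2nc3cc(Cl)c(Cl)cc3[nH]2)cc1`, gives 17000 nM in this assay; there is no single-point step between compound 2 and compound 1, only the two values themselves. For the measured compounds named here, compound 3, `O=C(CN1CCCCC1)Nc1ccc(-c2nc3ccccc3[nH]2)cc1`, gives 31000 nM in this assay, and the one measured step in the set, a 5.2-fold higher number from compound 1 to compound 3 (0.71 log units; beyond the scatter), concerns the ring substituent and not the amide side chain.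

The unmeasured compound is compound 4, `O=C(CCl)Nc1ccc(-c2nc3cc(C(F)(F)F)ccc3[nH]2)cc1`. Its difference from compound 1 is chloro in place of piperidin-1-yl on a saturated chain carbon bound to a carbonyl carbon. Going by the values given here, no measured step in the set touches this part of the molecule, so the only direct anchor for compound 4 is the value of compound 1 in this assay, 6000 nM. The measured step in the ring substituent says nothing about how a change on the amide side chain moves the number.

With nothing to pull the expectation in either direction, compound 4 is estimated to stay close to compound 1, with the step expected as a 1.2-fold lower number from compound 1 to compound 4 (0.08 log units; within the scatter), well inside what a fresh measurement might show. Compound 4 is therefore estimated at 5000 nM, with a range from 1200 nM to 20000 nM.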

Compound 4, half-maximal cytotoxic concentration: 5000 nM
The estimate for compound 4 equals the measured number at the digits printed; the range from low to high includes it.
By their numbers in this assay, from the lowest: compounds 4 and 1 (each within the scatter of the next); then compounds 2 and 3 (each within the scatter of the next).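

In this assay, among these compounds, the first change at this place, chloro in place of piperidin-1-yl on a saturated chain carbon bound to a carbonyl carbon, gives a 1.2-fold lower number from compound 1 to compound 4 (0.08 log units; within the scatter) and so leaves the two compounds within the scatter of each other. Among the compounds shown here, with the trifluoromethyl group in place, the six-membered non-aromatic ring of the piperidin-1-yl group can therefore be lost without a reading that separates compound 4 from compound 1, whereas the one step on the ring substituent, a 5.2-fold higher number from compound 1 to compound 3 (0.71 log units; beyond the scatter), lies beyond the scatter. No measured evidence bears on why this exchange leaves the two numbers together.

On these data alone, it remains open how a primary amine, a carboxylic acid or a longer chain on this same carbon would read in this assay, so the result covers only the chloro and piperidin-1-yl groups. Also open, as far as these compounds go, is whether hydrogen in place of trifluoromethyl would shift the number with chloro on the chain as it does with piperidin-1-yl there.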